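Dichloroacetamides on a biphenyl scaffold: where a fluoro is dropped

This account rests on a few compounds, and the source may have more. Where it says the series, first, only, none or still open, it means among the compounds named here.

Measured so far:
Compound 1 `CSc1cccc(-c2cc(NC(=O)C(Cl)Cl)cc(-c3cccc(SC)c3)c2)c1`: in a functional assay on KB 3-1 cells (Homo sapiens) for cytotoxicity, read by MTT assay, with a stated time of 68 h (a lower number here means a stronger inhibitor, a higher number a weaker inhibitor), compound 1 gives > 30000 nM, a limit of the assay rather than a number.
Compound 2 `O=C(Nc1cccc(-c2cccc(F)c2)c1)C(Cl)Cl`: in this assay compound 2 gives > 50000 nM, again only a limit.
Compound 3 `CC(C)c1ccc(-c2cc(NC(=O)C(Cl)Cl)cc(-c3ccc(C(C)C)cc3)c2)cc1`: in this assay compound 3 gives > 30000 nM, also a limit.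

All three compounds carry the same dichloroacetamide group on a shared core, and none of them reaches a measurable value in this assay. Compound 2 stands at the limit of > 50000 nM in this assay, at which 1 of the 3 values shown sits, while the other two sit at the limit of > 30000 nM in this assay, at which 2 of the 3 values shown sit; since every value shown is a limit, nothing separates the three compounds from one another.

Compound 4 `O=C(Nc1cccc(-c2ccccc2)c1)C(Cl)Cl`, the unmeasured compound, differs from compound 2 only in this way: hydrogen in place of fluoro on an aromatic carbon. Among the measured compounds shown here, no measured pair of compounds differs by this change, so the expected size of the step in this assay rests on the fact that all three measured compounds fall beyond the range of the assay; given the limit of > 50000 nM in this assay, at which 1 of the 3 values shown sits, for compound 2, the step is expected to be none beyond the scatter. Compound 4 is therefore estimated at 60000 nM (range 20000 nM to 200000 nM), most likely again reported only as a limit, with an expected step that the limit leaves unreadable from compound 2 to compound 4.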

Compound 4, half-maximal inhibitory concentration: 46800 nM
Estimate against measurement, compound 4: 1.3-fold (0.11 log units) above; the measured number falls inside the stated range.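

In this assay, among the compounds shown here, compound 4 gives 46800 nM, the only one of the four values shown that is a true number and not a limit of the assay. Hydrogen in place of fluoro on this aromatic carbon gives an at least 1.0-fold lower number from compound 2 to compound 4 (0.02 log units; that floor lies within the scatter), so the change brings no step that can yet be told apart from the scatter. From the compounds shown here alone, that step is only a floor, and its true size stays unknown because compound 2 carries just a limit: the limit of > 50000 nM in this assay, at which 1 of the 4 values shown sits.

The compounds shown leave open whether another group on this aromatic carbon, such as an amine or a methoxy group, would move the number. Going by these compounds, whether a plain acetamide in place of the dichloroacetamide would change the reading also stays open.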